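Ortho substituent swap on the shared core

The source may report more compounds than this note shows. Statements on the series, on what has been measured and on what is new or still open speak of the compounds shown alone.

Compound 1 `CCNC(=O)c1ccccc1CCC(SCC(CC)C(=O)O)c1cccc(OCc2ccc3ccc(Cl)cc3n2)c1` gives 0.45 nM in an assay on membranes from lung for binding affinity to cysteinyl leukotriene receptor 1 (Cavia porcellus); on this read-out lower numbers stand for stronger inhibition and higher numbers for weaker inhibition; that is the second highest of three numbers. Compound 2 `O=C(O)CCSC(CCc1ccccc1-c1nc[nH]n1)c1cccc(OCc2ccc3ccc(Cl)cc3n2)c1` gives 0.36 nM, and compound 3 `O=C(O)CCSC(CCc1ccccc1)c1cccc(OCc2ccc3ccc(Cl)cc3n2)c1` gives 6.5 nM. For the measured compounds named here, the one step with a single change, an 18-fold higher number from compound 2 to compound 3 (1.26 log units; beyond the scatter), shows that the group on the aromatic carbon carries much of the affinity. Compound 4 `CCC(CSC(CCc1ccccc1-c1nnnn1C)c1cccc(OCc2ccc3ccc(Cl)cc3n2)c1)C(=O)O` differs from compound 1 by 1-methyl-1H-tetrazol-5-yl in place of ethylcarbamoyl on an aromatic carbon. Going by the values given here, no measured step covers this exact exchange; the closest guide is that compound 1 and compound 2, carrying two different groups at that carbon, both sit near the low end. A step of a 1.1-fold higher number from compound 1 to compound 4 (0.05 log units; within the scatter) is therefore expected for compound 4, none beyond the scatter. The estimate for compound 4 is 0.5 nM, within 0.15 nM to 1.6 nM.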

Compound 4, half-maximal inhibitory concentration: 0.4 nM
Beside the measured number, compound 4's estimate is 1.3-fold (0.10 log units) above it, within the range that was stated.
By their numbers in this assay, from the lowest: compounds 2, 4 and 1 (each within the scatter of the next); then compound 3.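

In this assay, for the compounds shown here, the exchange gives a 1.1-fold lower number from compound 1 to compound 4 (0.05 log units; within the scatter), the first direct reading of two groups at this aromatic carbon on the same core. The hydrogen-bond donor counted on ethylcarbamoyl is absent from 1-methyl-1H-tetrazol-5-yl, yet compound 1 and compound 4 cannot be told apart, so on this core that donor is not required for the low number. No measurement on hand gives a reason for this result.

Still open, going by these compounds, is whether an amine or a carboxylic acid at this carbon would keep the number, and whether a longer chain on the amide nitrogen would do so.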